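Swapping the Amine Side of a Chalcone Core

This account rests on a few compounds, and the source may have more. Where it says the series, first, only, none or still open, it means among the compounds named here.

The shared core here carries a three-carbon chain with a carbonyl and a double bond, ending in an aromatic ring that changes from compound to compound. For the measured compounds named here, in a functional assay on HCT-116 cells (Homo sapiens) for antiproliferative activity, read by MTT assay, with a stated time of 24 h (on this read-out lower numbers stand for stronger inhibition and higher numbers for weaker inhibition), compound 1 `COc1ccc(C(=O)/C=C/c2ccc(N(C)C)cc2)c2c1C=CC(C)(C)O2` gives 1920 nM, the only outright number among the three measured compounds. Compound 2 `COc1ccc(C(=O)/C=C/c2ccc(N(c3ccccc3)c3ccccc3)cc2)c2c1C=CC(C)(C)O2` reaches only the limit of this assay, > 10000 nM. Compound 3 `COc1ccc(C(=O)/C=C/c2ccc(C(F)(F)F)cc2)c2c1C=CC(C)(C)O2` likewise stops at the limit, > 10000 nM. Going by the values given here, the one comparable step, an at least 5.2-fold higher number from compound 1 to compound 3 (0.71 log units; beyond the scatter), shows that losing the dimethylamino group from the aromatic ring costs activity, with the limit of > 10000 nM in this assay, at which 2 of the 3 values shown sit, marking how far that loss can be followed.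

Compound 4 `COc1ccc(C(=O)/C=C/c2cc(Cl)ccc2O)c2c1C=CC(C)(C)O2` is the next compound in this series. Compared with compound 1 the change is 5-chloro-2-hydroxyphenyl in place of 4-(dimethylamino)phenyl on a double-bonded chain carbon bound to a double-bonded chain carbon. Among the compounds with values here, no measured pair mirrors this exact exchange; the nearest guide is the step from compound 1 to compound 3, in which removing the dimethylamino group weakened inhibition beyond the scatter. Within the data shown here, since compound 4 also loses that group, a weaker result is expected, though the hydroxyl and chlorine it gains have no measured counterpart here, so the size is uncertain. Compound 4 is therefore estimated at 6000 nM, within 1500 nM to 20000 nM, a step of a 3.1-fold higher number from compound 1 to compound 4 (0.49 log units; beyond the scatter) that is expected but not yet seen.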

Compound 4, half-maximal inhibitory concentration: 5240 nM
Beside the measured number, compound 4's estimate is 1.1-fold (0.06 log units) above it, and the stated range covers the measured number.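

Placing 5-chloro-2-hydroxyphenyl in place of 4-(dimethylamino)phenyl on a double-bonded chain carbon bound to a double-bonded chain carbon gives a 2.7-fold higher number from compound 1 to compound 4 (0.44 log units; beyond the scatter) in this assay, so this change also costs activity, but the loss can now be read as an actual size. For the compounds shown here, compound 4 is the first compound besides compound 1 to give an outright number, which shows that a ring without the dimethylamino group can still register in this test, while the ceiling remains for the others: the limit of > 10000 nM in this assay, at which 2 of the 4 values shown sit. The entering group has no nitrogen, and it brings a hydroxyl and a chlorine, with 1 hydrogen-bond donor where the leaving group has 0, so activity at this place does not depend entirely on an amine.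

The compounds shown cannot separate the hydroxyl from the chlorine, since a ring carrying only one of the two would be needed for that. They also leave open whether a cyclic amine such as morpholine or piperidine, or a methoxy group, could match or better compound 1 at this place.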